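From a Phenoxy to a Phenyl Group on the Shared Core

The source may hold more compounds than are shown below. What is called first, only, known or untested is meant among the compounds shown, and "the series" means these compounds.

Of the compounds shown here, three built on one shared core have been measured in an assay for inhibition of Amine oxidase [flavin-containing] A (Homo sapiens), read by fluorescence and spectrophotometry, using microsomes, with stated times of 30 min and 20 min; a higher number here means a weaker inhibitor, a lower number a stronger inhibitor. Compound 1 `Clc1cccc(-c2nc(-c3cccc(C4=NCCN4)c3)no2)c1` gives 1390 nM, compound 2 `CC(C)(C)c1ccc(-c2noc(-c3ccc(C4=NCCN4)cc3)n2)cc1` gives 751 nM, and compound 3 `c1ccc(Oc2ccc(-c3noc(-c4ccc(C5=NCCN5)cc4)n3)cc2)cc1` gives 2770 nM. Compound 3 carries the highest of these three numbers; its gap to compound 1 lies within the scatter, whereas the step of a 3.7-fold higher number from compound 2 to compound 3 (0.57 log units; beyond the scatter) lies beyond it. The next compound, compound 4 `c1ccc(-c2ccc(-c3noc(-c4ccc(C5=NCCN5)cc4)n3)cc2)cc1`, is not yet measured and differs from compound 3 by a single change: phenyl in place of phenoxy on an aromatic carbon. Among the compounds with values here, only one measured step bears on this, the exchange of the group on that aromatic carbon seen in a 3.7-fold higher number from compound 2 to compound 3 (0.57 log units; beyond the scatter), which was modest in size. It shows that swapping this group can move the number by a modest amount, but it says nothing specific about a phenyl. The expectation is a modest shift toward lower numbers with wide uncertainty, as the estimated step of a 1.5-fold lower number from compound 3 to compound 4 (0.19 log units; within the scatter). Compound 4 is expected to give about 1800 nM in this assay, within a range from 600 nM to 5500 nM.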

Compound 4, half-maximal inhibitory concentration: > 100000 nM
Compound 4: only a limit was reported; the forecaster's own chance of this, stated with the estimate: 5%; middle value at least 55-fold (1.74 log units) from the limit.
By their numbers in this assay, from the lowest: compounds 2, 1 and 3 (each within the scatter of the next, the first and the last beyond it). At a limit, above all of these: compound 4.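

Replacing phenoxy with phenyl on this aromatic carbon, para to a large group, removes only the oxygen atom from the count, yet it gives an at least 36-fold higher number from compound 3 to compound 4 (1.55 log units; beyond the scatter) in this assay and shows that this position can move the number much further than the earlier modest step suggested. Measured against tert-butyl, the same phenyl gives an at least 130-fold higher number from compound 2 to compound 4 (2.12 log units; beyond the scatter) and so tert-butyl and phenoxy both give measured values here, while phenyl does not. Compound 4 stands at a limit of the assay and not at a number, so both steps give only minimum sizes: the limit of > 100000 nM in this assay, at which 1 of the 4 values shown sits.

How far compound 4 lies past that limit, and why phenyl differs so sharply from phenoxy, stays unknown. As far as these compounds go, whether a methoxy group, a chlorine atom or an amine at this place would give a measured value also stays open.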